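The source may hold more compounds than are shown below. What is called first, only, known or untested is meant among the compounds shown, and "the series" means these compounds.

Working notes on the series, read in a physicochemical assay for solubility, read by HPLC, in phosphate buffer, measured as kinetic solubility, with a stated time of 1 h, at pH 7.4, tested at 250 uM; on this read-out lower numbers stand for lower solubility and higher numbers for higher solubility. Compound 1 `CN1CCC(c2ccc3c(c2)oc(=O)n3C(=O)NCCCCc2ccc(F)cc2)CC1` gives 22000 nM. Compound 2 `CN1CCC(c2ccc3c(c2)oc(=O)n3C(=O)NCCCCc2ccccc2)CC1=O` gives 20000 nM, which lies within the usual scatter of the value for compound 1. Compound 3 `CCCCCNC(=O)n1c(=O)oc2cc(-c3ccc(F)cc3)ccc21` gives < 1000 nM, which is a limit of the assay and not a number. Compound 4 `CCN1CCN(c2ccc3c(c2)oc(=O)n3C(=O)NCCCCc2ccccc2)CC1` is not yet measured: 4-ethylpiperazin-1-yl in place of 1-methyl-2-oxopiperidin-4-yl on an aromatic carbon. Within the data shown here, no measured step covers this change. The expectation rests on compound 1 at 22000 nM and compound 2 at 20000 nM, which read alike with different six-membered non-aromatic rings at that place. The expected step of a 1.3-fold higher number from compound 2 to compound 4 (0.10 log units; within the scatter) is estimated to stay within the scatter. For compound 4 the estimated value is 25000 nM, with an expected range of 10000 nM to 70000 nM.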

Compound 4, solubility: < 1000 nM
Compound 4: a limit, no number; the forecaster's own chance of this, stated with the estimate: 10%; middle value at least 25-fold (1.39 log units) from the limit.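

This place on the aromatic carbon is not indifferent to the six-membered non-aromatic ring it carries: 4-ethylpiperazin-1-yl in place of 1-methyl-2-oxopiperidin-4-yl gives an at least 20-fold lower number from compound 2 to compound 4 (1.30 log units; beyond the scatter) in this assay. Compound 4 stands at a limit and not at a number: the limit of < 1000 nM in this assay, at which 2 of the 4 values shown sit.

Which part of the change carries the step stays open: the ring nitrogens, the ethyl group or the loss of the carbonyl. A 4-methylpiperazin-1-yl or a morpholin-4-yl group at this place would help to separate these.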